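Piperazine amides: human liver microsome stability, first two compounds

The source may report more compounds than this note shows. Statements on the series, on what has been measured and on what is new or still open speak of the compounds shown alone.

Measured so far in an ADME assay (liver) for metabolic stability, with Liver microsome (Homo sapiens) as the target, read by LC-MS, using microsomes, with a stated time of 1 h, tested at 5 uM; on this read-out lower numbers stand for a less stable compound and higher numbers for a more stable compound:
- compound 1, `Cc1nc(-c2ccccc2)c(C(=O)N2CCN(c3cccc(C#N)c3)CC2)o1`: 8%
- compound 2, `COc1cc(OC)cc(N2CCN(C(=O)c3oc(C)nc3-c3ccc(F)cc3)CC2)c1`: 12.9%

Both compounds share a methyl-oxazole carboxamide core carrying an aryl group on the second piperazine nitrogen. In this assay compound 1 gives 8%, the lower of the two numbers, while compound 2 gives 12.9%; the gap between them lies within the scatter, so the two are not distinguished. Both read as poorly stable.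

The next compound is compound 3, `Cc1nc(-c2ccccc2)c(C(=O)N2CCN(c3cc(Cl)cc(Cl)c3)CC2)o1`. It differs from compound 1 by one change: 3,5-dichlorophenyl in place of 3-cyanophenyl on an amine nitrogen in a ring. Going by the values given here, no measured pair with a single change of this kind exists, so the step cannot be read off from data. The two measured compounds, with different aryl groups on the amine nitrogen, both sit at low remaining percentages, which gives no reason to expect a step beyond the scatter in either direction.

For compound 3 the estimate in this assay is 7%, with a range from 2% to 18%. The expected step is a number 1 percentage points lower from compound 1 to compound 3 (within the scatter), that is, no change beyond the scatter.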

Compound 3, percent of the compound remaining: 66.3%
The estimate for compound 3 lay 59.3 percentage points below the measured number; the measured number lies above the stated range.
By their numbers in this assay, from the lowest: compounds 1 and 2 (each within the scatter of the next); then compound 3.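

Working notes: in this assay, replacing 3-cyanophenyl with 3,5-dichlorophenyl on an amine nitrogen in a ring gives a number 58.3 percentage points higher from compound 1 to compound 3 (beyond the scatter), with the rest of the structure of compound 1 unchanged. Going by these compounds alone, this is the first single-change pair, and it shows that the read-out responds strongly to the aryl group at this position, which the low numbers of the first two compounds, differing in more than one place, could not reveal. Nothing measured here accounts for the size of this step, so the change can be recorded but not explained.

The pair does not separate the loss of the nitrile from the arrival of the two chlorines, and a plain phenyl group or a phenyl group with a single chlorine on the same amine nitrogen would help to divide the step between them. It also leaves open whether two methyl groups in place of the two chlorines would give a similar number, and whether 3,5-dichlorophenyl gives a comparable step on the shared core when the aryl group of compound 2 is carried elsewhere in the structure.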